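Replacing the Piperidine Amide with a Methylbenzyl Group

A few compounds are considered here, and "the series" means these few. Any claim that something is new, unique, unknown or untested is made for them only; others in the source may bear on it.

Compound 1 `COc1cc(OC)c(-c2nc3cc(/C=C4\SC(=O)N(CC(=O)N5CCOCC5)C4=O)ccc3[nH]2)cc1OC`: 1120 nM
Compound 2 `COc1cc(-c2nc3cc(/C=C4\SC(=O)N(CC(=O)N5CCCCC5)C4=O)ccc3[nH]2)cc(OC)c1OC`: 3650 nM
Compound 3 `COc1cc(OC)c(-c2nc3cc(/C=C4\SC(=O)N(CC(=O)N5CCCCC5)C4=O)ccc3[nH]2)cc1OC`: 8760 nM

In a functional assay on HT-1080 cells (Homo sapiens) for inhibition, read by MTT assay, with a stated time of 48 h (on this read-out higher numbers stand for weaker inhibition and lower numbers for stronger inhibition), compound 3 gives 8760 nM, the highest number of the three. The nearer step is a 2.4-fold higher number from compound 2 to compound 3 (0.38 log units; beyond the scatter); the wider one is a 7.8-fold higher number from compound 1 to compound 3 (0.89 log units; beyond the scatter). Compound 4 `COc1cc(OC)c(-c2nc3cc(/C=C4\SC(=O)N(Cc5cccc(C)c5)C4=O)ccc3[nH]2)cc1OC` differs from compound 3 by 3-methylphenyl in place of (piperidin-1-yl)carbonyl on a saturated chain carbon bound to an amide-type nitrogen in a ring. Neither measured step bears on this change: one exchanges the ring inside the amide, the other moves a methoxy group on the aryl ring, and none removes the amide altogether. For the measured compounds named here, with no guiding precedent, the estimate for compound 4 is a 2.9-fold lower number from compound 3 to compound 4 (0.47 log units; beyond the scatter), a wide and uncertain guess. Compound 4 is therefore expected near 3000 nM, within 600 nM to 15000 nM.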

Compound 4, half-maximal inhibitory concentration: 190 nM
Compound 4: middle estimate off by 16-fold (1.20 log units), on the high side; the whole stated range lies above it.
By their numbers in this assay, from the lowest: compound 4; then compound 1; then compound 2; then compound 3.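

In this assay, for the compounds shown here, replacing the amide on this saturated chain carbon with an aromatic ring gives a 46-fold lower number from compound 3 to compound 4 (1.66 log units; beyond the scatter) and so shows that the (piperidin-1-yl)carbonyl is not required for inhibition here, which the earlier steps within the amide series could not show. The 3-methylbenzyl group also surpasses the morpholine amide, with a 5.9-fold lower number from compound 1 to compound 4 (0.77 log units; beyond the scatter) as the step. Nothing available explains this gain.

From the compounds shown here alone, whether the methyl group contributes remains open, since plain benzyl or pyridinylmethyl would be needed to test it. Also open, going by these compounds, is whether the gain holds with the 3,4,5-trimethoxyphenyl group of compound 2.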